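Chain-terminal amine swap: compound 2 to compound 3

A few compounds are considered here, and "the series" means these few. Any claim that something is new, unique, unknown or untested is made for them only; others in the source may bear on it.

Measured so far in a functional assay on PC-3 cells (Homo sapiens) for antiproliferative activity, read by MTT assay, with a stated time of 72 h; a higher number here means a weaker inhibitor, a lower number a stronger inhibitor:
- compound 1 `COc1cc2ncnc(N3CCc4ccccc43)c2cc1NC(=O)/C=C/C(C)C`: 6530 nM
- compound 2 `CCN(CC)C/C=C/C(=O)Nc1cc2c(N3CCc4ccccc43)ncnc2cc1OC`: 3690 nM

Going by the values given here, compound 2 carries the lower of the two numbers, but its only neighbour, compound 1, is separated from it by a 1.8-fold lower number from compound 1 to compound 2 (0.25 log units; within the scatter), so the two cannot be placed in order. That step put (diethylamino)methyl in place of isopropyl on a double-bonded chain carbon bound to a double-bonded chain carbon.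

Compound 3 `COc1cc2ncnc(N3CCc4ccccc43)c2cc1NC(=O)/C=C/CN1CCC(CO)CC1` is not yet measured. It differs from compound 2 in one place: 4-(hydroxymethyl)piperidin-1-yl in place of diethylamino on a saturated chain carbon bound to a double-bonded chain carbon. Among the compounds with values here, the only measured step that touches this end of the chain is a 1.8-fold lower number from compound 1 to compound 2 (0.25 log units; within the scatter), which exchanged the whole terminal group and still stayed within the scatter. No measured pair compares one amine with another at this place, so nothing shown supports a step beyond the scatter in either direction in this assay. Compound 3 is therefore expected to give 3200 nM in this assay, with a range of 1200 nM to 9000 nM. This estimate means a step of a 1.2-fold lower number from compound 2 to compound 3 (0.06 log units; within the scatter), which is expected to stay within the scatter.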

Compound 3, half-maximal inhibitory concentration: 2650 nM
The estimate for compound 3 lay 1.2-fold (0.08 log units) above the measured number, and the stated range covers the measured number.
By their numbers in this assay, from the lowest: compounds 3, 2 and 1 (each within the scatter of the next, the first and the last beyond it).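

In this assay, going by these compounds alone, the first comparison of one amine with another at this place gives a 1.4-fold lower number from compound 2 to compound 3 (0.14 log units; within the scatter), so 4-(hydroxymethyl)piperidin-1-yl and diethylamino on a saturated chain carbon bound to a double-bonded chain carbon cannot be told apart here, although the entering group adds a six-membered non-aromatic ring and a hydrogen-bond donor. Measured against the isopropyl end of compound 1, the same group gives a 2.5-fold lower number from compound 1 to compound 3 (0.39 log units; beyond the scatter), the only step shown that lies beyond the scatter, and a modest one, while compound 2 remains within the scatter of both compound 1 and compound 3. Nothing measured alongside these numbers bears on why the steps have this size.

Still open, as far as these compounds go, is whether plain piperidin-1-yl, without the hydroxymethyl group, would stay within the scatter of compound 3, which would separate the ring from the hydroxyl. Also open, from the compounds shown here alone, is whether morpholin-4-yl, piperazin-1-yl, a carboxylic acid or a longer chain at this end could give a step beyond the scatter from compound 2 or compound 3 in this assay, or whether this end of the chain allows only modest steps.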